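Anilino group variation on a shared brominated core

This account rests on a few compounds, and the source may have more. Where it says the series, first, only, none or still open, it means among the compounds named here.

Compound 1 `CNC(=O)c1ccccc1Oc1nc(Nc2cccc(C)c2)ncc1Br` gives 18600 nM in a functional assay on MDA-MB-468 cells (Homo sapiens) for antiproliferative activity, read by MTT assay, with a stated time of 24 h; a higher number here means a weaker inhibitor, a lower number a stronger inhibitor. Compound 2 `CNC(=O)c1ccccc1Oc1nc(Nc2ccc(Cl)cc2F)ncc1Br` gives > 50000 nM in this assay, which is a limit and not a number (the limit of > 50000 nM in this assay, at which 1 of the 2 values shown sits).

Within the data shown here, the one measured step, an at least 2.6-fold higher number from compound 1 to compound 2 (0.42 log units; beyond the scatter), reached that limit. Compound 3 `CNC(=O)c1ccccc1Oc1nc(Nc2cccc(OC)c2)ncc1Br` differs from compound 2 by 3-methoxyphenyl in place of 4-chloro-2-fluorophenyl on a nitrogen on an aromatic ring. The entering 3-methoxyphenyl stands nearer the 3-methylphenyl of compound 1 than the leaving group, so the change is expected to reverse the earlier rise. Compound 3 is therefore expected at 20000 nM, within 8000 nM to 50000 nM. The expected step is an at least 2.5-fold lower number from compound 2 to compound 3 (0.39 log units; beyond the scatter), a lower number.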

Compound 3, half-maximal inhibitory concentration: 17800 nM
For compound 3 the middle estimate is 1.1-fold (0.05 log units) above the measured one, within the range that was stated.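

Methoxy in place of methyl on an aromatic carbon gives a 1.0-fold lower number from compound 1 to compound 3 (0.02 log units; within the scatter), so these two groups cannot be told apart in this assay. The change of the anilino group gives an at least 2.8-fold lower number from compound 2 to compound 3 (0.44 log units; beyond the scatter), so the anilino group does matter here. The full size of this step cannot be read because compound 2 gives a limit, not a number: the limit of > 50000 nM in this assay, at which 1 of the 3 values shown sits.

On these data alone, whether the chlorine or the fluorine of compound 2 goes with the weaker reading stays open. As far as these compounds go, how an amine or a longer alkoxy chain on the phenyl ring would read also stays open.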